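Swapping an Aminophenyl for a Bromophenyl on the Core

The source may hold more compounds than are shown below. What is called first, only, known or untested is meant among the compounds shown, and "the series" means these compounds.

Within the data shown here, in a toxicity assay on NIH3T3 cells (Mus musculus) for cytotoxicity, read by resazurin assay (on this read-out lower numbers stand for an effect already at smaller amounts and higher numbers for an effect only at larger amounts of compound), compound 2 `COC(=O)c1ccc(NCc2cncn2Cc2ccccc2N)cc1-c1ccccc1` gives 25000 nM, the higher of the two numbers measured so far, while compound 1 `c1ccc(-c2ccc(Cn3cncc3CNc3cccc(-c4ccccc4)c3)cc2)cc1` gives 10000 nM, a gap that lies beyond the usual scatter. Compound 3 `COc1ccc(NCc2cncn2Cc2ccc(-c3ccccc3)cc2N)cc1-c1ccccc1` yields only a limit of the assay, reported as > 1000 nM (the limit of > 1000 nM in this assay, at which 1 of the 3 values shown sits). Compound 4 `COC(=O)c1ccc(NCc2cncn2Cc2ccc(Br)cc2)cc1-c1ccccc1` has not yet been measured; it differs from compound 2 in a single place: 4-bromophenyl in place of 2-aminophenyl on a saturated chain carbon bound to an aromatic nitrogen. Among the measured compounds shown here, no measured pair shows this particular change, so its size remains open. For compound 4 a modest shift toward lower numbers is expected, amounting to a 1.7-fold lower number from compound 2 to compound 4 (0.22 log units; within the scatter). Compound 4 is therefore estimated at 15000 nM, with a likely range from 5000 nM to 40000 nM.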

Compound 4, half-maximal effective concentration: > 10000 nM
Compound 4: a limit, no number; the forecaster's own chance of this, stated with the estimate: 20%; the middle value is on the limit's open side.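

Among these compounds, compound 4 gives > 10000 nM, which is a limit of the assay and not a number, so no step from compound 2 to compound 4 can be read. The compounds shown leave open how far 4-bromophenyl in place of 2-aminophenyl shifts the number in this assay.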